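Chalcone series: phenolic oxygen substituent and cytotoxicity on K562 cells

The source may hold more compounds than are shown below. What is called first, only, known or untested is meant among the compounds shown, and "the series" means these compounds.

Measured so far:
compound 1 `COc1ccc(/C=C/C(=O)c2ccc(OC)c3c2OC(C)(C)C=C3)cc1O` — 630 nM
compound 2 `COc1ccc(/C=C/C(=O)c2ccc(OC)c3c2OC(C)(C)C=C3)cc1OCCCN(C)C` — 2920 nM

Going by the values given here, in a functional assay on K562 cells (Homo sapiens) for cytotoxicity, read by MTT assay (on this read-out higher numbers stand for weaker inhibition and lower numbers for stronger inhibition), compound 2 gives the higher of the two numbers; the only comparison is the one to compound 1, which is a 4.6-fold higher number from compound 1 to compound 2 (0.67 log units; beyond the scatter). That step is the single measured one that touches the oxygen on the aromatic ring in question, and it shows that putting the 3-(dimethylamino)propyl group there moved the number beyond the scatter, upward.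

Compound 3 `COc1ccc(/C=C/C(=O)c2ccc(OC)c3c2OC(C)(C)C=C3)cc1OC(=O)CCl` has not been measured. Its difference from compound 2 is (chloromethyl)carbonyl in place of 3-(dimethylamino)propyl on an oxygen on an aromatic ring. Among the compounds with values here, the group that leaves is the same one whose entry defined the step from compound 1 to compound 2; the group that enters has no measured counterpart, so nothing here tells how (chloromethyl)carbonyl itself compares with hydrogen on that oxygen.

Expectation: removing 3-(dimethylamino)propyl is expected to move the number back toward that of compound 1, so for compound 3 a step of about a 3.2-fold lower number from compound 2 to compound 3 (0.51 log units; beyond the scatter) is estimated, downward, beyond the scatter. Compound 3 is therefore estimated at 900 nM, with a range from 300 nM to 2700 nM, the width reflecting the absence of any measured ester on this oxygen.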

Compound 3, half-maximal inhibitory concentration: 400 nM
For compound 3 the middle estimate is 2.3-fold (0.35 log units) above the measured one; the measured number falls inside the stated range.
By their numbers in this assay, from the lowest: compounds 3 and 1 (each within the scatter of the next); then compound 2.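

In this assay, the oxygen on the aromatic ring now has a second measured substituent, and the change gives a 7.3-fold lower number from compound 2 to compound 3 (0.86 log units; beyond the scatter) when (chloromethyl)carbonyl replaces 3-(dimethylamino)propyl, so the higher number of the 3-(dimethylamino)propyl compound does not extend to every group placed on this oxygen. Set against hydrogen on the same oxygen, the change gives a 1.6-fold lower number from compound 1 to compound 3 (0.20 log units; within the scatter) and so cannot be told apart from the free phenol in this read-out, which shows that hydrogen on this oxygen can be replaced by (chloromethyl)carbonyl without a step beyond the scatter. No measurement bears on the cause of either step.

The compounds shown do not separate the contributions of the terminal dimethylamino group, the propyl chain and the ether link in compound 2, and a simple methyl ether or a shorter chain ending in the same amine would address that. Nor do they show whether the chlorine of compound 3 matters, which a plain acetyl ester on this oxygen would test directly.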